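Series notes: cytotoxicity, chloro to methoxy on the aryl ring

The source may report more compounds than this note shows. Statements on the series, on what has been measured and on what is new or still open speak of the compounds shown alone.

Three compounds measured in an ADME assay on NIH3T3 cells (Mus musculus) for cytotoxicity, read by MTT assay, with a stated time of 24 h (on this read-out higher numbers stand for weaker inhibition and lower numbers for stronger inhibition), lie close together. Compound 3 `O=C(CSc1ncccn1)N/N=c1/scc(-c2ccc(Cl)cc2)n1-c1ccccc1` gives 397 ug/mL; compound 2 `COc1ccc(-c2cs/c(=N/NC(=O)CSc3nnc(C)s3)n2-c2ccccc2)cc1` gives 300 ug/mL; compound 1 `O=C(CSc1ncccn1)N/N=c1/scc(-c2ccc(Br)cc2)n1-c1ccccc1` gives 273 ug/mL. Compound 3 is within the scatter of both others. Within the data shown here, the one step measured, a 1.5-fold higher number from compound 1 to compound 3 (0.16 log units; within the scatter), is itself within the scatter.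

Compound 4 `COc1ccc(-c2cs/c(=N/NC(=O)CSc3ncccn3)n2-c2ccccc2)cc1` differs from compound 3 by methoxy in place of chloro on an aromatic carbon. Among the measured compounds shown here, no measured step bears directly on methoxy in place of chloro; compound 2, which carries methoxy on a different core, and compound 3 show values within the scatter of each other. No step beyond the scatter is therefore expected in this assay. Compound 4 is estimated at 350 ug/mL, range 180 ug/mL to 700 ug/mL, a step of a 1.1-fold lower number from compound 3 to compound 4 (0.05 log units; within the scatter) expected to stay within the scatter.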

Compound 4, half-maximal inhibitory concentration: 450 ug/mL
For compound 4 the middle estimate is 1.3-fold (0.11 log units) below the measured one, within the range that was stated.
By their numbers in this assay, from the lowest: compounds 1, 2, 3 and 4 (each within the scatter of the next).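

Among these compounds, the first direct reading of 4-chlorophenyl to 4-methoxyphenyl in this assay is a 1.1-fold higher number from compound 3 to compound 4 (0.05 log units; within the scatter) and the reading for methoxy in place of bromo is a 1.6-fold higher number from compound 1 to compound 4 (0.22 log units; within the scatter) so this aromatic carbon carries chloro, bromo and methoxy with no step beyond the scatter. On the sulfur, pyrimidin-2-yl in place of 5-methyl-1,3,4-thiadiazol-2-yl gives a 1.5-fold higher number from compound 2 to compound 4 (0.18 log units; within the scatter) and likewise stays within the scatter. No measurement shown accounts for these readings.

From the compounds shown here alone, whether an amine or a carboxylic acid on this aromatic carbon would give a step beyond the scatter remains open.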